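Chloro on the phenyl ring of compound 1

A few compounds are considered here, and "the series" means these few. Any claim that something is new, unique, unknown or untested is made for them only; others in the source may bear on it.

Compound 1 `COc1ccc2[nH]c(-c3nc(-c4ccccc4)no3)cc2c1` in a functional assay on MCF7 cells (Homo sapiens) for antiproliferative activity, read by WST assay, with a stated time of 72 h (a higher number here means a weaker inhibitor, a lower number a stronger inhibitor), gives > 50000 nM, which is a limit of the assay and not a number.
Compound 2 `Fc1ccc2[nH]c(-c3nc(-c4ccccc4)no3)cc2c1` in this assay gives 35000 nM.
Compound 3 `O=[N+]([O-])c1ccc2[nH]c(-c3nc(-c4ccccc4)no3)cc2c1` in this assay gives > 50000 nM, again a limit of the assay and not a number.

Compound 1 therefore stands only at a limit, and the same holds for most of the set: the limit of > 50000 nM in this assay, at which 2 of the 3 values shown sit. Only compound 2 has a number, and the steps between the measured compounds are small or unreadable: an at least 1.4-fold lower number from compound 1 to compound 2 (0.15 log units; that floor lies within the scatter), a step that the two limits leave unreadable from compound 1 to compound 3, and an at least 1.4-fold higher number from compound 2 to compound 3 (0.15 log units; that floor lies within the scatter). All three steps swap the group on the shared core; none touches the phenyl ring.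

Compound 4 `COc1ccc2[nH]c(-c3nc(-c4ccc(Cl)cc4)no3)cc2c1` differs from compound 1 in that phenyl ring only: chloro in place of hydrogen on an aromatic carbon. Going by the values given here, no measured step bears on this change, so the measured compounds give no ground to expect a step beyond the scatter in this assay, in either direction. The estimate for compound 4 is 50000 nM, between 15000 nM and 200000 nM. This estimate, expected for compound 4, amounts to a number no higher from compound 1 to compound 4 (the limit leaves the size open), with a sizeable chance that only a limit is reported once more.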

Compound 4, half-maximal inhibitory concentration: > 50000 nM
Compound 4: only a limit was reported; the forecaster's own chance of this, stated with the estimate: 60%; the middle value lies on the limit itself.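

Compound 4 in this assay gives > 50000 nM, a limit of the assay and not a number. Going by these compounds alone, compound 1 also stands at a limit, so no step between these two compounds can be read, and most of the set now sits there: the limit of > 50000 nM in this assay, at which 3 of the 4 values shown sit. On these data alone, whether chloro on the phenyl ring changes this activity at all stays open.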